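The source may report more compounds than this note shows. Statements on the series, on what has been measured and on what is new or still open speak of the compounds shown alone.

Measured so far:
- compound 1 `Cc1cc(S(=O)(=O)N2CCC(CCCC(=O)NO)CC2)cc2ccccc12`: 17300 nM
- compound 2 `O=C(CCCC1CCN(S(=O)(=O)c2cccc(C(F)(F)F)c2)CC1)NO`: "not determined" (no result reported)
- compound 3 `O=C(CCCC1CCN(S(=O)(=O)c2ccc(-c3cnco3)cc2)CC1)NO`: "not determined" (no result reported)

Among the compounds with values here, in a functional assay on HCT-116 cells (Homo sapiens) for inhibition, read by resazurin assay, with a stated time of 5 days (on this read-out higher numbers stand for weaker inhibition of growth and lower numbers for stronger inhibition of growth), compound 1 gives 17300 nM, the only number; compound 2 and compound 3 carry no result in this assay, so compound 1 cannot be placed against any neighbour, and no step between measured compounds can be drawn.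

Compound 4 `O=C(CCCC1CCN(S(=O)(=O)c2ccc3ccccc3c2)CC1)NO` is the unmeasured partner of compound 1. The difference between them is hydrogen in place of methyl on an aromatic carbon. Within the data shown here, no step of this kind has been measured, so the expectation rests on the size of the change alone: a single carbon leaves a fused aromatic ring while the sulfonamide, the piperidine, the chain and the hydroxamic acid are kept. A change this small is expected to move the read-out in this assay little, if at all, in either direction, with the estimated step from compound 1 to compound 4 of a 1.2-fold lower number from compound 1 to compound 4 (0.06 log units; within the scatter) lying within the usual scatter. Compound 4 is therefore expected to give about 15000 nM in this assay, within a range from 5000 nM to 45000 nM.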

Compound 4, concentration for 50% growth inhibition: 1900 nM
The estimate for compound 4 lay 7.9-fold (0.90 log units) above the measured number; the measured number lies below the stated range.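

Hydrogen in place of methyl on this aromatic carbon, ortho to a fused ring, gives a 9.1-fold lower number from compound 1 to compound 4 (0.96 log units; beyond the scatter) in this assay, so the lower number, and with it the stronger inhibition of growth, goes with hydrogen. This position is therefore not silent in the series: one carbon leaves, no hydrogen-bond donor or acceptor is counted in the change, no net charge is involved, and the rest of the core stays the same, yet the step lies beyond the scatter. No measurement bears on what lies behind this step, which rests on a single pair of compounds.

Open, as far as these compounds go, is whether fluorine, chlorine, methoxy or ethyl on this carbon would stay with methyl or with hydrogen. Also open, from the compounds shown here alone, is whether the same step appears when a longer chain replaces the one in the core.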